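Chain lengthening on a quinone-type scaffold, tested for cytotoxicity

The compounds below may be only part of what the source reports. "The series", "measured", "known", "first", "only" and "open" are said of these compounds alone.

Of the compounds shown here, three have been measured in a functional assay on L1210 cells (Mus musculus) for cytotoxicity; a lower number here means that less compound is needed, a higher number that more compound is needed for the effect. Compound 1 `CCC(O)c1cc(OC)c2c(c1OC)C(=O)C=CC2=O` gives 0.085 ug/mL. Compound 2 `CCCCCCCC(O)c1cc(OC)c2c(c1OC)C(=O)C=CC2=O`, which differs from it by pentyl in place of hydrogen on a saturated chain carbon, three bonds along the chain from an aromatic carbon and an oxygen on a saturated carbon, gives 0.274 ug/mL; that change produced a 3.2-fold higher number from compound 1 to compound 2 (0.51 log units; beyond the scatter). Compound 3 `COc1ccc(OC)c2c1C(=O)C=C(C(C)O)C2=O` has a different core, and the difference between the two cores is not broken down here; in this assay compound 3 gives 0.487 ug/mL.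

Compound 4 `CCCCCCC(O)C1=CC(=O)c2c(OC)ccc(OC)c2C1=O` has not yet been measured. It arises from compound 3 by pentyl in place of hydrogen on a saturated chain carbon, two bonds along the chain from a double-bonded ring carbon and an oxygen on a saturated carbon. This is the same kind of change as that from compound 1 to compound 2, but not the same: there the place was three bonds along the chain from an aromatic carbon, here it is two bonds along the chain from a double-bonded ring carbon. Because the earlier change gave a 3.2-fold higher number from compound 1 to compound 2 (0.51 log units; beyond the scatter), a step of similar size is expected here, namely a 2.9-fold higher number from compound 3 to compound 4 (0.46 log units; beyond the scatter), while the shift of place leaves room for it to come out somewhat smaller or larger. Compound 4 is therefore estimated to give 1.4 ug/mL, expected to lie between 0.6 ug/mL and 3.5 ug/mL.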

Compound 4, concentration for half-maximal effect: 0.732 ug/mL
Beside the measured number, compound 4's estimate is 1.9-fold (0.28 log units) above it; the measured number falls inside the stated range.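

In this assay, the pentyl change on the second core gives a 1.5-fold higher number from compound 3 to compound 4 (0.18 log units; within the scatter), so on this core the longer chain leaves the number within the usual spread of repeat measurements. Set beside the step on the first core, the two results cannot be told apart: the same change on two cores in this assay, a 3.2-fold higher number (0.51 log units; beyond the scatter) from compound 1 to compound 2 and a 1.5-fold higher number (0.18 log units; within the scatter) from compound 3 to compound 4, 2.1-fold (0.33 log units) apart, within the scatter of two such steps. Going by these compounds alone, this fits one shared effect of the change on both cores, but it does not show that the step carries over unchanged: only two pairs are available, one step lies beyond the scatter and the other within it, and the place of the change differs between them.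

Still open, from the compounds shown here alone, is how the number would respond on either core if pentyl were replaced by a butyl group, a longer chain, an amine or a carboxylic acid. No two compounds shown differ in the core alone, so what the core itself contributes also remains unsettled.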